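Deacetylation steps in a carbamate macrolide series

The compounds below may be only part of what the source reports. "The series", "measured", "known", "first", "only" and "open" are said of these compounds alone.

Compound 1 `C=C/C=C\[C@H](C)[C@H](OC(N)=O)[C@@H](C)[C@H](O)[C@@H](C)C/C(C)=C\[C@H](C)[C@@H](O)[C@@H](C)/C=C\[C@H](C[C@@H]1OC(=O)[C@H](C)[C@@H](OC(C)=O)[C@H]1C)OC(C)=O` gives 0.74 nM in a functional assay on P388 cells (Mus musculus) for cytotoxicity, read by MTT assay, with a stated time of 48 h (a higher number here means a weaker inhibitor, a lower number a stronger inhibitor), the lowest of the two numbers measured. Compound 2 `C=C/C=C\[C@H](C)[C@H](OC(N)=O)[C@@H](C)[C@H](O)[C@@H](C)C/C(C)=C\[C@H](C)[C@@H](O)[C@@H](C)/C=C\[C@@H](O)C[C@@H]1OC(=O)[C@H](C)[C@@H](OC(C)=O)[C@H]1C` gives 12.6 nM in this assay; the step of a 17-fold higher number from compound 1 to compound 2 (1.23 log units; beyond the scatter) is the only measured one in the series. Compound 3 `C=C/C=C\[C@H](C)[C@H](OC(N)=O)[C@@H](C)[C@H](O)[C@@H](C)C/C(C)=C\[C@H](C)[C@@H](O)[C@@H](C)/C=C\[C@H](C[C@@H]1OC(=O)[C@H](C)[C@@H](O)[C@H]1C)OC(C)=O` differs from compound 1 by hydrogen in place of acetyl on an oxygen on a saturated carbon. Among the measured compounds shown here, the one measured step also removes an acetyl and was large, so a weakening is expected here, though the size of this second removal is unknown. Compound 3 is therefore expected at 4 nM, between 1 nM and 20 nM. The expected step is a 5.4-fold higher number from compound 1 to compound 3 (0.73 log units; beyond the scatter).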

Compound 3, half-maximal inhibitory concentration: 3.9 nM
Estimate against measurement, compound 3: 1.0-fold (0.01 log units) above; low and high end bracket the measured number.
By their numbers in this assay, from the lowest: compound 1; then compound 3; then compound 2.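

Acetoxy to hydroxy on the saturated carbon whose other neighbour is a saturated ring carbon weakens the result in this assay, with a 5.3-fold higher number from compound 1 to compound 3 (0.72 log units; beyond the scatter), so the acetyl at this place also counts. The other acetyl removal gave a 17-fold higher number from compound 1 to compound 2 (1.23 log units; beyond the scatter), so the same exchange is modest here and large there, and its size depends on the place. No measured evidence accounts for this difference.

As far as these compounds go, whether a methyl ether, an amine or a longer acyl chain on this oxygen-bearing carbon would keep the potency of compound 1 remains open. From the compounds shown here alone, the effect of losing both acetyl groups together also remains open.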